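The source may report more compounds than this note shows. Statements on the series, on what has been measured and on what is new or still open speak of the compounds shown alone.

Two compounds have been measured in an assay (Cricetulus griseus) for inhibition of aldehyde dehydrogenase, mitochondrial (Homo sapiens); a higher number here means a weaker inhibitor, a lower number a stronger inhibitor:

compound 1, `NCCCCCCOc1ccc2c(=O)c(-c3ccc(O)cc3)coc2c1`, gives 100 nM;
compound 2, `O=C(O)COc1ccc2c(=O)c(-c3ccc(O)cc3)coc2c1`, gives 1200 nM.

Going by the values given here, compound 2 stands with the highest number of the two; its only neighbour is compound 1, and the step of a 12-fold higher number from compound 1 to compound 2 (1.08 log units; beyond the scatter) is large and lies beyond the scatter. Compound 3, `O=C(O)CCCCCCOc1ccc2c(=O)c(-c3ccc(O)cc3)coc2c1`, has not yet been measured. It differs from compound 2 in one place: 5-carboxypentyl in place of carboxy on a saturated chain carbon bound to an oxygen on an aromatic ring. Among the compounds with values here, the one measured step that bears on this change is a 12-fold higher number from compound 1 to compound 2 (1.08 log units; beyond the scatter), in which a carboxy group took the place of the longer 5-aminopentyl group on the same chain carbon. Compound 3 brings back a chain of the same length as in compound 1 while keeping the carboxy end, so part of that step is expected to be undone in this assay, though the terminal group still differs from that of compound 1 and a full return is not expected. Compound 3 is therefore expected to give 400 nM in this assay, within a range of 150 nM to 1200 nM, which means an expected step of a 3.0-fold lower number from compound 2 to compound 3 (0.48 log units; beyond the scatter).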

Compound 3, half-maximal inhibitory concentration: 50 nM
Estimate against measurement, compound 3: 8.0-fold (0.90 log units) above; the whole stated range lies above it.
By their numbers in this assay, from the lowest: compounds 3 and 1 (each within the scatter of the next); then compound 2.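

In this assay, going by these compounds alone, the carboxy end does not by itself set the weak number of compound 2: going to 5-carboxypentyl at the same place gives a 24-fold lower number from compound 2 to compound 3 (1.38 log units; beyond the scatter), a large step that the earlier compounds could not show. Exchanging the end group with the chain held constant gives a 2.0-fold lower number from compound 1 to compound 3 (0.30 log units; within the scatter), which lies within the scatter, so carboxy in place of amino at the chain end makes no readable difference here, and the large step between compound 1 and compound 2 can now be seen to go with the change in the chain rather than with the end group alone. Nothing available explains either step.

The compounds shown leave open how the number moves at chain lengths between carboxy and 5-carboxypentyl, and whether a longer chain keeps it low. They also leave open whether any end group is needed at all, since a plain alkyl chain ending in a methyl group, a primary amide or a hydroxyl at the chain end could each read differently from the amine and the carboxylic acid.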